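Nicotinamide phosphoribosyltransferase inhibitors: sulfonamide aryl variation

The compounds below may be only part of what the source reports. "The series", "measured", "known", "first", "only" and "open" are said of these compounds alone.

Measured so far:
compound 1 `O=C(/C=C/c1cccnc1)NCCCCCCCc1ccc(S(=O)(=O)Nc2ccccc2)cc1`: 16.4 nM
compound 2 `Cc1ccccc1NS(=O)(=O)c1cccc(CCCCCCNC(=O)/C=C/c2cccnc2)c1`: 5.08 nM

For the measured compounds named here, in an assay on isolated protein for inhibition of Nicotinamide phosphoribosyltransferase (Homo sapiens), read by WST assay, with stated times of 60 min, 5 min and 30 min, in the presence of a further agent that is not named here (on this read-out lower numbers stand for stronger inhibition and higher numbers for weaker inhibition), compound 2 gives 5.08 nM, the lower of the two numbers known; compound 1 gives 16.4 nM, a difference beyond the usual scatter. Compound 3 `O=C(/C=C/c1cccnc1)NCCCCCCc1cccc(S(=O)(=O)Nc2ccc(F)c(Cl)c2)c1` is not yet measured. It differs from compound 2 by 3-chloro-4-fluorophenyl in place of 2-methylphenyl on a sulfonamide nitrogen. Going by the values given here, no measured pair shows the effect of this change, so the expected step of a 1.2-fold higher number from compound 2 to compound 3 (0.07 log units; within the scatter) is set at none beyond the scatter. Compound 3 is therefore estimated at 6 nM, with a range from 2 nM to 20 nM, pending the measurement.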

Compound 3, half-maximal inhibitory concentration: 9.7 nM
Estimate against measurement, compound 3: 1.6-fold (0.21 log units) below; measured number inside the range.
By their numbers in this assay, from the lowest: compounds 2, 3 and 1 (each within the scatter of the next, the first and the last beyond it).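

In this assay, 3-chloro-4-fluorophenyl in place of 2-methylphenyl on a sulfonamide nitrogen gives a 1.9-fold higher number from compound 2 to compound 3 (0.28 log units; within the scatter), so this one pair does not separate the two aryl groups. The sulfonamide nitrogen thus carries either group without a change beyond the scatter. Nothing available explains this result.

Compound 1 differs from both others in more than one place, so it adds nothing on this change. From the compounds shown here alone, whether a cyclohexyl group or a pyridine ring on this nitrogen would read the same remains open.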